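The compounds below may be only part of what the source reports. "The series", "measured", "known", "first", "only" and "open" are said of these compounds alone.

Measured compounds in a functional assay on the whole organism for inhibition, with Chenopodium ficifolium as the target, with a stated time of 72 h, tested at 100 mg/L; a lower number here means less inhibition of growth, a higher number more inhibition of growth at the concentration tested:
compound 1, `COc1cc(SC)nc(NC(=S)NC(=O)c2c(-c3ccc(Cl)cc3Cl)noc2C)n1`, giving 60.3%;
compound 2, `COc1cc(Cl)nc2n/c(=N/C(=O)c3c(-c4ccc(Cl)cc4Cl)noc3C)sn12`, giving 65.9%;
compound 3, `COc1cc(C)nc(NC(=S)NC(=O)c2c(-c3ccc(Cl)cc3Cl)noc2C)n1`, giving 59.8%.

Compound 3 holds the lowest of the three numbers, but its nearest neighbour on the numbers, compound 1, sits within the scatter of it, and so does compound 2, the furthest. The three measured values therefore form one flat group in this assay.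

The next compound, compound 4, `CSc1cc(C)nc(NC(=S)NC(=O)c2c(-c3ccc(Cl)cc3Cl)noc2C)n1`, has not yet been measured. It differs from compound 3 in one place: methylsulfanyl in place of methoxy on an aromatic carbon.

Within the data shown here, the only measured step that touches the same ring is a number 0.5 percentage points lower from compound 1 to compound 3 (within the scatter). That step exchanged groups at a different carbon and left the number where it was. Among the measured compounds shown here, no measured pair exchanges methoxy for methylsulfanyl, so the closest guide is the finding that small changes on this ring did not move the number beyond the scatter. On that basis no step beyond the scatter is expected in this assay from compound 3 to compound 4. Compound 4 is expected to give about 62%, within 50% to 74%, which would be an estimated step of a number 2.2 percentage points higher from compound 3 to compound 4 (within the scatter).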

Compound 4, percent growth inhibition at one concentration: 86.1%
Compound 4: the middle estimate sits 24.1 percentage points below what was measured, and the stated range ends below it.
By their numbers in this assay, from the lowest: compounds 3, 1 and 2 (each within the scatter of the next); then compound 4.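

In this assay, among these compounds, the methoxy group proves to matter at a place where the earlier compounds showed no sensitivity: a number 26.3 percentage points higher from compound 3 to compound 4 (beyond the scatter), and a number 25.8 percentage points higher from compound 1 to compound 4 (beyond the scatter). The earlier step between compound 1 and compound 3 had exchanged methylsulfanyl for methyl with methoxy kept on the ring and stayed within the scatter, so among these three compounds the number rises only when methoxy leaves and the 4-methyl-6-(methylsulfanyl)pyrimidin-2-yl group results, which means that neither methylsulfanyl nor methyl alone accounts for the higher number in compound 4. No measurement available here gives a reason for this rise.

The compounds shown cannot separate the loss of methoxy from the particular pairing of methyl with methylsulfanyl, and a ring carrying two methyl groups or two methylsulfanyl groups would bear directly on that question. From the compounds shown here alone, it also remains open how far this place tolerates other groups, such as an ethylsulfanyl chain, an amine or a chlorine, and whether the higher number of compound 4 holds at other concentrations.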